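The source may report more compounds than this note shows. Statements on the series, on what has been measured and on what is new or still open speak of the compounds shown alone.

Measured compounds and their numbers in an ADME assay on Caco-2 cells (Homo sapiens) for permeability, in the apical to basolateral direction; on this read-out higher numbers stand for higher permeability and lower numbers for lower permeability:

Compound 1, `Cn1cnc(S(=O)(=O)N2CCC(CN(C3Cc4cc(C#N)ccc4N(Cc4cncn4C)C3)S(=O)(=O)c3ccccn3)CC2)c1`: 0.1 10^-6 cm/s
Compound 2, `Cn1cncc1CN1CC(N(CC2CCN(C(=O)N3CCCCC3)CC2)S(=O)(=O)c2ccccn2)Cc2cc(C#N)ccc21`: 0.6 10^-6 cm/s
Compound 3, `Cn1cncc1CN1CC(N(Cc2cccc(-n3cccc3)c2)S(=O)(=O)c2ccccn2)Cc2cc(C#N)ccc21`: 2.3 10^-6 cm/s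

Among these three, compound 2 stands second highest. Compound 3 is its nearest neighbour, and its number is above that of compound 2; compound 1 is furthest, well below. Among the compounds with values here, the one step that has been measured within this set, a 6.0-fold higher number from compound 1 to compound 2 (0.78 log units; beyond the scatter), concerns a change on the amine nitrogen in a ring and does not touch the carbonyl substituent that is now in question.

Compound 4, `Cn1cncc1CN1CC(N(CC2CCN(C(=O)c3cccs3)CC2)S(=O)(=O)c2ccccn2)Cc2cc(C#N)ccc21`, is the unmeasured compound. It differs from compound 2 in one place: thiophen-2-yl in place of piperidin-1-yl on a carbonyl carbon. Within the data shown here, no measured step shows what swapping a piperidin-1-yl for a thiophen-2-yl on this carbonyl carbon does in this assay, so the expectation rests on the spread of the three numbers alone. Compound 3, which carries an aromatic group in this region of the molecule, sits above compound 2 but not far beyond it. The step from compound 2 to compound 4 is therefore expected to be small, a 1.5-fold higher number from compound 2 to compound 4 (0.18 log units; within the scatter), with the direction uncertain. Compound 4 is estimated at 0.9 10^-6 cm/s, within a range from 0.3 10^-6 cm/s to 2.5 10^-6 cm/s.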

Compound 4, apparent permeability: 0.5 10^-6 cm/s
For compound 4 the middle estimate is 1.8-fold (0.26 log units) above the measured one; low and high end bracket the measured number.
By their numbers in this assay, from the lowest: compound 1; then compounds 4 and 2 (each within the scatter of the next); then compound 3.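

In this assay, thiophen-2-yl on the carbonyl carbon in place of piperidin-1-yl gives a step within the scatter (a 1.2-fold lower number from compound 2 to compound 4 (0.08 log units; within the scatter)), so these two groups are not told apart at this place, even though one is a five-membered aromatic ring and the other a six-membered non-aromatic ring. The change from the sulfonyl group of compound 1 now has a second carbonyl example: (thiophen-2-yl)carbonyl in place of (1-methyl-1H-imidazol-4-yl)sulfonyl on an amine nitrogen in a ring gives a step beyond the scatter (a 5.0-fold higher number from compound 1 to compound 4 (0.70 log units; beyond the scatter)), in the same direction as the step to the piperidin-1-yl carbonyl compound (a 6.0-fold higher number from compound 1 to compound 2 (0.78 log units; beyond the scatter)). Nothing available here accounts for either result.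

From the compounds shown here alone, it remains open whether a carbonyl group bearing an open-chain amine such as dimethylamino, or a thiophen-2-yl ring carrying a carboxylic acid, would also stay within the scatter of compound 2. Going by these compounds, it is also open whether the step from compound 1 follows the sulfonyl link itself or its 1-methyl-1H-imidazol-4-yl group, a question that a piperidin-1-yl sulfonyl group would address.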